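Indazole in place of the lactone on compound 1

A few compounds are considered here, and "the series" means these few. Any claim that something is new, unique, unknown or untested is made for them only; others in the source may bear on it.

Compound 1 `O=C1OCc2cc(N(Cc3ccc(C4CCCCC4)cn3)C(=O)[C@H]3CCN3S(=O)(=O)c3c(F)c(F)c(F)c(F)c3F)ccc21` and compound 2 `O=C(NO)c1ccc(N(Cc2ccc(C3CCCCC3)cc2)C(=O)[C@H]2CCN2S(=O)(=O)c2c(F)c(F)c(F)c(F)c2F)cc1` carry the same acyl azetidine core with a pentafluorophenyl sulfonyl group. In a functional assay on MCF7 cells (Homo sapiens) for antiproliferative activity, with a stated time of 72 h (a lower number here means that less compound is needed, a higher number that more compound is needed for the effect), compound 1 gives 4600 nM and compound 2 gives 6800 nM; the two numbers lie within the usual scatter of one another, so no order can be read between them. In this assay compound 3 `O=C(NO)c1ccc(N(Cc2ccc(C3CCCCC3)cc2)C(=O)[C@H]2CCN2S(=O)(=O)c2c(F)c(F)c(F)c(F)c2F)c(F)c1` gives "not determined" (no result reported), so no number is available for it. Compound 4 `O=C([C@H]1CCN1S(=O)(=O)c1c(F)c(F)c(F)c(F)c1F)N(Cc1ccc(C2CCCCC2)cn1)c1cc2[nH]ncc2cc1F` differs from compound 1 by a group of 10 heavy atoms (7 carbon, 2 nitrogen, 1 fluorine; one five-membered aromatic ring with 2 hetero atoms, one six-membered aromatic ring of carbon only) in place of a group of 10 heavy atoms (8 carbon, 2 oxygen; one five-membered non-aromatic ring with 1 hetero atom, one six-membered aromatic ring of carbon only), on an amide-type nitrogen. For the measured compounds named here, no measured pair shows the effect of this kind of change, so the step is expected to stay near zero, with wide uncertainty in either direction. Compound 4 is therefore estimated at 3500 nM (range 900 nM to 14000 nM), a step of a 1.3-fold lower number from compound 1 to compound 4 (0.12 log units; within the scatter) that is expected to remain close to the scatter.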

Compound 4, half-maximal effective concentration: 4800 nM
For compound 4 the middle estimate is 1.4-fold (0.14 log units) below the measured one; measured number inside the range.
By their numbers in this assay, from the lowest: compounds 1, 4 and 2 (each within the scatter of the next).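

In this assay the 5-fluoro-1H-indazol-6-yl group on the amide-type nitrogen, in place of the group carried by compound 1, gives a 1.0-fold higher number from compound 1 to compound 4 (0.02 log units; within the scatter) and so no readable difference. For the compounds shown here, this is the first pair that differs in one place, and the entering group brings a hydrogen-bond donor that the leaving group lacks, with the step still within the scatter. Nothing available bears on this result.

Going by these compounds, whether an amine or a carboxylic acid on this nitrogen's ring would give a step beyond the scatter stays open. On these data alone, the share of the fluorine in 5-fluoro-1H-indazol-6-yl also stays open.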